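Removing the Methoxyphenyl Arm from Compound 3

A few compounds are considered here, and "the series" means these few. Any claim that something is new, unique, unknown or untested is made for them only; others in the source may bear on it.

Among the measured compounds shown here, compound 3 `COc1ccc(-c2cc(C(=O)NC3CCCCCC3)c(OCc3ccc(F)cc3)nc2C)cc1` is the only member of this small set with a measured number: in an assay on HEK293 cells for inhibition of Monoacylglycerol lipase ABHD6 (Homo sapiens), read by scintillation counting, with stated times of 30 min and 5 min (a higher number here means a weaker inhibitor, a lower number a stronger inhibitor), compound 3 gives 530 nM. Compound 1 `Cc1ccc(C(=O)NC2CCCCCC2)c(=O)n1Cc1ccc(F)cc1` reaches only a limit of the assay, giving > 10000 nM in this assay. Compound 2 `Cc1c(Br)cc(C(=O)NC2CCCCCC2)c(=O)n1Cc1ccc(F)cc1` likewise stops at a limit, with > 10000 nM in this assay. For the measured compounds named here, the one step between measured neighbours, a step that the two limits leave unreadable from compound 1 to compound 2, cannot be sized because both ends sit at the limit of > 10000 nM in this assay, at which 2 of the 3 values shown sit. Compound 4 `Cc1ccc(C(=O)NC2CCCCCC2)c(OCc2ccc(F)cc2)n1` differs from compound 3 by hydrogen in place of 4-methoxyphenyl on an aromatic carbon. Going by the values given here, no measured step covers this removal, so the measured steps give no direct guide; what remains is that compound 1 and compound 2 lack such an aryl arm and fall at the limit, while compound 3 carries it and gives a number. On that footing the step of a 28-fold higher number from compound 3 to compound 4 (1.45 log units; beyond the scatter) is expected to be a loss of potency beyond the scatter. For compound 4 the estimate in this assay is 15000 nM, ranging from 3000 nM to 80000 nM, with a real chance that only a limit is reported.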

Compound 4, half-maximal inhibitory concentration: > 10000 nM
Compound 4: a limit, no number; the forecaster's own chance of this, stated with the estimate: 60%; the middle value lies beyond the limit too.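

Among the compounds shown here, replacing the 4-methoxyphenyl group with hydrogen on this aromatic carbon gives an at least 18-fold higher number from compound 3 to compound 4 (1.27 log units; beyond the scatter) in this assay, the first readable step in this set. The earlier compounds shown here offered no step with a number at one end, whereas this one shows that, on this shared core, the 4-methoxyphenyl group at this position goes with a measurable inhibition and its removal with a large loss. Compound 4 stops at a limit, not a number, so the step gives only a minimum size: the limit of > 10000 nM in this assay, at which 3 of the 4 values shown sit.

The compounds shown leave open how much of the arm is needed, for example whether a plain phenyl group without the methoxy or a small methyl group on this carbon would keep a measurable number. On these data alone, whether the methoxy group itself contributes also stays unknown.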